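Trifluoromethyl in place of pyridin-3-yl on the shared core

This account rests on a few compounds, and the source may have more. Where it says the series, first, only, none or still open, it means among the compounds named here.

Among the compounds with values here, compound 2 `c1cncc(-c2nnc(-c3c[nH]c4ccccc34)o2)c1` gives 170000 nM in a functional assay on DU-145 cells (Homo sapiens) for cytotoxicity, read by MTT assay (a higher number here means a weaker inhibitor, a lower number a stronger inhibitor), and is the only compound of the three with a number rather than a limit. Compound 1 `c1ccc(-c2nnc(-c3c[nH]c4ccccc34)o2)cc1` sits in this assay at > 1000000 nM, which is a limit. Compound 3 `COc1ccc(-c2nnc(-c3c[nH]c4ccccc34)o2)cc1OC` likewise sits in this assay at > 1000000 nM, also a limit. Within the data shown here, the one measured step, an at least 5.8-fold lower number from compound 1 to compound 2 (0.76 log units; beyond the scatter), runs from a limit to a number, so only its lower bound is known. Compound 4 `FC(F)(F)c1nnc(-c2c[nH]c3ccccc23)o1` differs from compound 2 by trifluoromethyl in place of pyridin-3-yl on an aromatic carbon. Among the measured compounds shown here, no measured step covers this exact change; the step from compound 1 to compound 2 shows that pyridin-3-yl yields a number where phenyl does not, and compound 3 with dimethoxyphenyl stays at the same limit, as summarised in the limit of > 1000000 nM in this assay, at which 2 of the 3 values shown sit. Removing the pyridin-3-yl altogether is expected to move compound 4 back toward that limit, a step of a 2.9-fold higher number from compound 2 to compound 4 (0.47 log units; beyond the scatter). Compound 4 is therefore estimated at 500000 nM in this assay, between 120000 nM and 2000000 nM, with a real chance that only a limit is reported.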

Compound 4, half-maximal inhibitory concentration: > 1000000 nM
Compound 4 gave a limit, no number; the forecaster's own chance of this, stated with the estimate: 45%; middle value at least 2.0-fold (0.30 log units) from the limit.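

Trifluoromethyl in place of pyridin-3-yl on this aromatic carbon gives an at least 5.8-fold higher number from compound 2 to compound 4 (0.76 log units; beyond the scatter) in this assay, so a small group without a ring does not keep the measurable value seen with compound 2. Within the data shown here, compound 1, compound 3 and compound 4 all stand at a limit, which leaves compound 2 as the only compound with a number and pyridin-3-yl as the only group here linked to one: the limit of > 1000000 nM in this assay, at which 3 of the 4 values shown sit. The step from compound 1 to compound 4 joins two limits and cannot be read, so phenyl and trifluoromethyl cannot be ranked against each other.

Going by these compounds, whether the gain depends on where the ring nitrogen sits remains open, and pyridin-2-yl or pyridin-4-yl would address that. Also open, on these data alone, is whether an amine or a carboxylic acid on this carbon would give a number.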